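The compounds below may be only part of what the source reports. "The series", "measured", "known", "first", "only" and "open" are said of these compounds alone.

Of the compounds shown here, three built on one shared core have been measured so far. Compound 1 `Nc1cc(N)c2nc(-c3ccccc3)c(Oc3ccc(Cl)c(Cl)c3)nc2c1` gives 3020 nM in a functional assay on PC-3 cells (Homo sapiens) for inhibition, read by sulforhodamine B assay, with a stated time of 48 h; a higher number here means a weaker inhibitor of growth, a lower number a stronger inhibitor of growth. Compound 2 `COc1ccc(CNc2nc3cc(N)cc(N)c3nc2-c2ccccc2)cc1OC` gives 8320 nM in this assay, and compound 3 `CCOC(=O)[C@H](CCC(=O)O)NC(=O)c1ccc(Sc2nc3cc(N)cc(N)c3nc2-c2ccccc2)cc1` gives 15100 nM. Compound 1 thus stands at the lowest number of the three, and its gaps to compound 2 and to compound 3 are both wider than the usual scatter of this kind of measurement, so compound 1 is the strongest inhibitor of growth among them.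

The next compound, compound 4 `Nc1cc(N)c2nc(-c3ccccc3)c(Sc3ccc(F)cc3)nc2c1`, differs from compound 1 in one place: (4-fluorophenyl)sulfanyl in place of 3,4-dichlorophenoxy on an aromatic carbon. Among the measured compounds shown here, no pair of measured compounds shows this particular exchange, so nothing measured tells directly how large the step will be. The step from compound 1 to compound 4 is expected to be small, at most a modest weakening, as described by a 1.5-fold higher number from compound 1 to compound 4 (0.17 log units; within the scatter). On that basis compound 4 is estimated to give about 4500 nM in this assay, with a plausible range from 1500 nM to 13000 nM.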

Compound 4, concentration for 50% growth inhibition: < 100000 nM
Compound 4: a limit, no number; the forecaster's own chance of this, stated with the estimate: 5%; the middle value lies beyond the limit too.
By their numbers in this assay, from the lowest: compound 1; then compounds 2 and 3 (each within the scatter of the next).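

For compound 4 the result is a limit and not a number, so the size of the step from compound 1 to compound 4 cannot be read: the limit of < 100000 nM in this assay, at which 1 of the 4 values shown sits. As far as these compounds go, whether (4-fluorophenyl)sulfanyl in place of 3,4-dichlorophenoxy changes growth inhibition, and by how much, stays open.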